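The source may hold more compounds than are shown below. What is called first, only, known or untested is meant among the compounds shown, and "the series" means these compounds.

Compound 1 `O=C(NCCNS(=O)(=O)c1ccc(-c2ccccc2OCc2cccc(O)c2)s1)Nc1cc(Cl)cc(Cl)c1`: > 20000 nM (a limit)
Compound 2 `O=[N+]([O-])c1cccc(NC(=S)NCCNS(=O)(=O)c2ccc(-c3ccccc3OCc3cccc(O)c3)s2)c1`: 13800 nM

Going by the values given here, in an ADME assay on HEK-293T cells (Homo sapiens) for cytotoxicity, read by CCK-8 assay, with a stated time of 48 h (on this read-out higher numbers stand for weaker inhibition and lower numbers for stronger inhibition), compound 2 gives 13800 nM, the only actual number so far. Compound 3 `Cc1cc(C)cc(NC(=O)NCCNS(=O)(=O)c2ccc(-c3ccccc3OCc3cccc(O)c3)s2)c1` differs from compound 2 by one exchange: a group of 11 heavy atoms (9 carbon, 1 nitrogen, 1 oxygen; one six-membered aromatic ring of carbon only) in place of a group of 12 heavy atoms (7 carbon, 2 nitrogen, 2 oxygen, 1 sulfur; one six-membered aromatic ring of carbon only), on an amine nitrogen. Among the compounds with values here, the one measured step bearing on this exchange, also made on an amine nitrogen, is an at least 1.4-fold lower number from compound 1 to compound 2 (0.16 log units; that floor lies within the scatter). On that evidence, no change beyond the scatter is expected, and the estimated step is a 1.2-fold higher number from compound 2 to compound 3 (0.06 log units; within the scatter). A reading at the assay limit is also plausible. For compound 3 the expected value is 16000 nM, with an estimated range of 8000 nM to 32000 nM.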

Compound 3, half-maximal inhibitory concentration: > 20000 nM
Compound 3: no number, only a limit; the forecaster's own chance of this, stated with the estimate: 45%; middle value at least 1.2-fold (0.09 log units) from the limit.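

With the (3,5-dimethylphenyl)carbamoyl group on the amine nitrogen, this assay gives an at least 1.4-fold higher number from compound 2 to compound 3 (0.16 log units; that floor lies within the scatter). Compound 3 gives a limit and not a number, as does compound 1, and the step between these two, 3,5-dimethylphenyl in place of 3,5-dichlorophenyl on an amide-type nitrogen, cannot be read. Any difference among these aryl groups is therefore hidden at the ceiling: the limit of > 20000 nM in this assay, at which 2 of the 3 values shown sit.

As far as these compounds go, the exchange from compound 2 to compound 3 alters both the aryl group and the thiocarbonyl, so the contribution of each stays open. A 3,5-dimethylphenyl thiourea would separate the two.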